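This account rests on a few compounds, and the source may have more. Where it says the series, first, only, none or still open, it means among the compounds named here.

Two compounds define the ground so far. Compound 1 `CN(C[C@@H]1CCCc2cc(S(=O)(=O)c3cccc(F)c3)ccc21)S(N)(=O)=O` gives 3.98 nM in an assay on isolated protein for displacement of a labelled ligand from 5-hydroxytryptamine receptor 6 (Homo sapiens); on this read-out lower numbers stand for stronger inhibition and higher numbers for weaker inhibition. Compound 2 `O=C(NC[C@@H]1CCCc2cc(S(=O)(=O)c3cccc(F)c3)ccc21)c1ccc[nH]1` gives 5.01 nM in this assay; it differs from compound 1 only in the group on the chain carbon, and the step of a 1.3-fold higher number from compound 1 to compound 2 (0.10 log units; within the scatter) leaves compound 2 standing next to compound 1 with no separation beyond the scatter. Compound 3 `O=C(NC[C@@H]1CCCc2cc(S(=O)(=O)c3cccc(F)c3)ccc21)c1ncc[nH]1` carries the same core as compound 2 and differs from it by 1H-imidazol-2-yl in place of 1H-pyrrol-2-yl on a carbonyl carbon. Among the measured compounds shown here, no measured step touches this ring: the only step known, a 1.3-fold higher number from compound 1 to compound 2 (0.10 log units; within the scatter), exchanges the whole substituent on the chain and says nothing about swapping one five-membered aromatic ring for another on the carbonyl carbon. With nothing in the data pointing either way, the expected change for compound 3 in this assay is a 1.4-fold higher number from compound 2 to compound 3 (0.15 log units; within the scatter), none beyond the scatter. Compound 3 is therefore estimated at 7 nM, within 2.5 nM to 25 nM.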

Compound 3, inhibition constant: 15.9 nM
For compound 3 the middle estimate is 2.3-fold (0.36 log units) below the measured one; the range from low to high includes it.
By their numbers in this assay, from the lowest: compounds 1 and 2 (each within the scatter of the next); then compound 3.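

In this assay, the ring on the carbonyl carbon proves to be a place where a small exchange counts: 1H-imidazol-2-yl in place of 1H-pyrrol-2-yl gives a 3.2-fold higher number from compound 2 to compound 3 (0.50 log units; beyond the scatter), although the ring stays five-membered and aromatic, keeps its hydrogen-bond donor and gains a hydrogen-bond acceptor. The chain substituent is also no longer interchangeable, since ((1H-imidazol-2-yl)carbonyl)amino in place of methyl(sulfamoyl)amino gives a 4.0-fold higher number from compound 1 to compound 3 (0.60 log units; beyond the scatter), a separation the earlier pair did not show. Nothing measured here accounts for either step.

The compounds shown leave open whether a phenyl, furan-2-yl or 1H-pyrazol-3-yl ring on the carbonyl carbon would stay with compound 2 or move towards compound 3. They also leave open what a methyl group on the imidazole ring nitrogen would do.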